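This account rests on a few compounds, and the source may have more. Where it says the series, first, only, none or still open, it means among the compounds named here.

Of the compounds shown here, two have so far been measured in an in vitro functional assay on HEK ts201 cells for antagonist activity at Neuronal acetylcholine receptor; alpha3/beta4 (Homo sapiens), read by fluorescence and calcium flux; a lower number here means a stronger inhibitor, a higher number a weaker inhibitor. Compound 1, `CC1CC(=O)N(c2ccccc2C(=O)OCC2CCCN(CCCCCc3ccccc3)C2)C1=O`, gives 4170 nM in this assay. Compound 2, `CN1CCCC(COC(=O)c2ccccc2-c2ccccc2)C1`, gives 4790 nM in this assay. The two numbers lie within the scatter of each other, so neither compound can be set above the other, and compound 1 simply has the lower of the two numbers.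

Compound 3, `CC1CC(=O)N(c2ccccc2C(=O)OCC2CCCN(CCCC3CCCCC3)C2)C1=O`, has not yet been measured in this assay. Relative to compound 1 it carries cyclohexyl in place of phenethyl on a saturated chain carbon, three bonds along the chain from an amine nitrogen in a ring. The cyclohexyl that enters is a non-aromatic ring where the phenethyl that leaves held an aromatic ring, and the chain is shorter by the count shown. For the measured compounds named here, no step between measured compounds bears on this change, so the expectation rests on compound 1 alone, read through its value 4170 nM. The step of a 1.2-fold lower number from compound 1 to compound 3 (0.08 log units; within the scatter) is expected to stay within the scatter. Compound 3 is estimated at 3500 nM, with a range from 1200 nM to 10000 nM.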

Compound 3, half-maximal inhibitory concentration: 10700 nM
For compound 3 the middle estimate is 3.1-fold (0.49 log units) below the measured one, and the stated range ends below it.
By their numbers in this assay, from the lowest: compounds 1 and 2 (each within the scatter of the next); then compound 3.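

Exchanging 5-phenylpentyl for 3-cyclohexylpropyl gives in this assay (a 2.6-fold higher number from compound 1 to compound 3 (0.41 log units; beyond the scatter)) a modest but real loss, so this place on the chain is not indifferent to what it carries. The change swaps an aromatic ring for a non-aromatic one and shortens the chain in the same step, so this one step cannot show how much of the loss belongs to the ring and how much to the chain length. Nothing available offers an explanation for the step.

The compounds shown leave open whether a 5-cyclohexylpentyl group, with the ring changed and the chain kept, or a 3-phenylpropyl group, with the chain shortened and the ring kept, would account for the loss. They also leave open how a pyridyl ring would fare at this place.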